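Swapping the chlorophenyl end of a diaryl urea

The source may hold more compounds than are shown below. What is called first, only, known or untested is meant among the compounds shown, and "the series" means these compounds.

Compound 1 `O=C(Nc1ccc(Cl)cc1)Nc1ccc(Oc2ccc(-c3nccs3)cc2)cc1` is one of two measured compounds built on the same shared core. In a functional assay on MDA-MB-231 cells (Homo sapiens) for inhibition, read by MTT assay and WST assay, with a stated time of 72 h, tested at 10 uM (on this read-out lower numbers stand for less inhibition of growth and higher numbers for more inhibition of growth at the one concentration tested), compound 1 gives 32.5%, the lower of the two numbers available. Compound 2 `O=C(Nc1ccc(Oc2ccc(-c3nccs3)cc2)cc1)Nc1ccc(F)c(C(F)(F)F)c1` differs from compound 1 only in the aryl ring attached to one urea nitrogen, and in this assay compound 2 gives 71.8%; the step of a number 39.3 percentage points higher from compound 1 to compound 2 (beyond the scatter) is large and beyond the scatter.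

Compound 3 `O=C(Nc1ccc(Oc2ccc(-c3nccs3)cc2)cc1)Nc1cc(Br)cc(C(F)(F)F)c1` has not yet been measured. It differs from compound 1 in one place: 3-bromo-5-(trifluoromethyl)phenyl in place of 4-chlorophenyl on an amide-type nitrogen. For the measured compounds named here, only the step from compound 1 to compound 2 bears on this change, since it also replaces the 4-chlorophenyl with a ring carrying a trifluoromethyl group together with a halogen, although the exact group entering is not the same one. That step, a number 39.3 percentage points higher from compound 1 to compound 2 (beyond the scatter), was large. For compound 3 a step upward beyond the scatter is therefore expected, estimated as a number 32.5 percentage points higher from compound 1 to compound 3 (beyond the scatter). Compound 3 is expected to give about 65%, with a range from 40% to 85%.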

Compound 3, percent growth inhibition at one concentration: 72.8%
For compound 3 the middle estimate is 7.8 percentage points below the measured one; low and high end bracket the measured number.
By their numbers in this assay, from the lowest: compound 1; then compounds 2 and 3 (each within the scatter of the next).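

In this assay a second ring carrying both trifluoromethyl and a halogen also gives a large rise over the 4-chlorophenyl ring, with a number 40.3 percentage points higher from compound 1 to compound 3 (beyond the scatter). The large gain at this position, on an amide-type nitrogen, therefore no longer rests on a single replacement, even though the two entering rings carry different halogens, bromine and fluorine, and the numbers in their names differ. Exchanging one of these rings for the other, with a number 1 percentage points higher from compound 2 to compound 3 (within the scatter), leaves the two compounds indistinguishable in this read-out, so this test at a single concentration does not separate these two substitution patterns.

Nothing available explains the rise from the 4-chlorophenyl ring to either of these rings, or why the two rings give such similar numbers. Still open, from the compounds shown here alone, is whether the trifluoromethyl group alone would be enough without a halogen on the ring, and how the number would respond to a nitrile in its place or to a ring carrying an amine or a carboxylic acid.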